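Swapping a propanoyl for a pent-1-en-1-yl on the shared core

The source may report more compounds than this note shows. Statements on the series, on what has been measured and on what is new or still open speak of the compounds shown alone.

Three compounds share one core. Compound 1 `CCC(=O)c1c(C)nn(CCCN2CCN(c3ccc(C)cc3)CC2)c(=O)c1N` gives 29% in a functional assay on the whole organism (Abdomen, strain Swiss) for inhibition, with Mus musculus as the target, with stated times of 30 min, 10 min and 5 min, at a dose of 40 mg/kg by the oral route (on this read-out lower numbers stand for a weaker effect and higher numbers for a stronger effect at the one dose given), and stands second highest of the three. Compound 2 `CCCC(=O)c1c(C)nn(CCCN2CCN(c3ccc(C)cc3)CC2)c(=O)c1N` gives 32%, and compound 3 `C=Cc1c(CCC)nn(CCCN2CCN(c3ccc(C)cc3)CC2)c(=O)c1N` gives 22%; both lie within the scatter of compound 1. Compound 4 `CCC/C=C/c1c(C)nn(CCCN2CCN(c3ccc(C)cc3)CC2)c(=O)c1N` is not yet measured. It differs from compound 1 as follows: pent-1-en-1-yl in place of propanoyl on an aromatic carbon. Going by the values given here, the only measured step, a number 3 percentage points higher from compound 1 to compound 2 (within the scatter), alters the chain and stays within the scatter, while compound 3, which also carries a carbon group with a double bond outside aromatic rings at that position, gives a value within the scatter of compound 1. No step beyond the scatter is therefore expected, a number 3 percentage points lower from compound 1 to compound 4 (within the scatter), and compound 4 is estimated at 26%, between 14% and 38%.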

Compound 4, a percentage reported as inhibition, in the whole organism at one dose (the size of the read-out at that dose, not a potency): 36%
The estimate for compound 4 lay 10 percentage points below the measured number; the range from low to high includes it.
By their numbers in this assay, from the lowest: compounds 3, 1, 2 and 4 (each within the scatter of the next, the first and the last beyond it).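

Replacing propanoyl with pent-1-en-1-yl on this aromatic carbon removes the carbonyl and its hydrogen-bond acceptor, yet the step is a number 7 percentage points higher from compound 1 to compound 4 (within the scatter) in this assay, so the effect at this one dose holds without that carbonyl. Replacing propylcarbonyl with the same group gives a number 4 percentage points higher from compound 2 to compound 4 (within the scatter) as its step, so neither ketone can be told apart from this all-carbon chain. Nothing shown here explains this result.

As far as these compounds go, whether an amine, a carboxylic acid or a longer chain at this position would move the number beyond the scatter remains open. So does what a saturated pentyl chain would give in place of pent-1-en-1-yl.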